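A few compounds are considered here, and "the series" means these few. Any claim that something is new, unique, unknown or untested is made for them only; others in the source may bear on it.

Compound 1 `CC1CCN(C2CCN(S(=O)(=O)c3ccc(C(C)(C)C)cc3)CC2)CC1` carries a tert-butyl group on the shared core. In a functional assay on DLD-1 cells (Homo sapiens) for antiproliferative activity, read by CellTiter-Glo, with a stated time of 72 h (on this read-out higher numbers stand for weaker inhibition and lower numbers for stronger inhibition), compound 1 gives > 5000 nM, which is a limit of the assay and not a number. Where compound 1 stands is told by the limit of > 5000 nM in this assay, at which 1 of the 2 values shown sits; of the two values shown, compound 1 is the one resting on that limit. The other measured compound, compound 2 `Cc1ccc(S(=O)(=O)N2CCC(N3CCC(C)CC3)CC2)cc1C`, has a number: in this assay compound 2 gives 24 nM. Compound 3 `CC1CCN(C2CCN(S(=O)(=O)c3ccc(-c4ccc(Cl)cc4)cc3)CC2)CC1` has not yet been measured in this assay. The change from compound 1 to compound 3 is 4-chlorophenyl in place of tert-butyl on an aromatic carbon. Among the measured compounds shown here, no step between two measured compounds is available to set the scale, so the size of this step can only be guessed from the fact that compound 2, which also carries an aromatic substituent on the shared core, gives 24 nM. Compound 3 is expected to land around 500 nM in this assay, with a plausible range from 50 nM to 5000 nM. The expected step of an at least 10-fold lower number from compound 1 to compound 3 (1.00 log units; beyond the scatter) would run toward stronger inhibition, though it remains uncertain whether the assay will report a number at all.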

Compound 3, half-maximal inhibitory concentration: 105 nM
Compound 3: the middle estimate sits 4.8-fold (0.68 log units) above what was measured, within the range that was stated.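

The step gives the first readable measure of what this position can do: with 4-chlorophenyl in place of tert-butyl on an aromatic carbon, para to a large group, this assay shows an at least 47-fold lower number from compound 1 to compound 3 (1.67 log units; beyond the scatter). The change to the shared core therefore matters greatly at this one place, and a group that adds a six-membered aromatic ring and a chlorine is compatible with stronger inhibition, whereas the tert-butyl of compound 1 gave no number. For compound 1, > 5000 nM is a limit of the assay and not a number, and the true size of the step stays unknown because of it: the limit of > 5000 nM in this assay, at which 1 of the 3 values shown sits.

What the compounds shown leave open is whether the gain belongs to the added ring or to its chlorine, a question that a plain phenyl or a 4-methoxyphenyl at this same place would address. They also leave open how other kinds of group would fare on this aromatic carbon, such as a primary amine, a carboxylic acid or a longer alkyl chain.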